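This account rests on a few compounds, and the source may have more. Where it says the series, first, only, none or still open, it means among the compounds named here.

Compound 1, `O[C@H]1CC[C@H]2CCN[C@H]2C1`: in an assay on HEK293 cells for antagonist activity at Nicotinic acetylcholine receptor alpha-4/beta-2 (Mus musculus), read by FLIPR, using a membrane potential dye (a higher number here means a weaker inhibitor, a lower number a stronger inhibitor), compound 1 gives > 100000 nM, a limit of the assay rather than a number.
Compound 2, `CO[C@H]1CC=C2CCN[C@H]2C1`: in this assay compound 2 gives 100000 nM.

For the measured compounds named here, compound 2 holds the only number among the two values shown; the other value is a limit. That limit belongs to compound 1, which sits at the limit of > 100000 nM in this assay, at which 1 of the 2 values shown sits. Compound 3, `O[C@H]1CC=C2CCN[C@H]2C1`, differs from compound 2 by hydrogen in place of methyl on an oxygen on a saturated carbon, a hydrogen in place of a methyl on an oxygen on a saturated carbon. Going by the values given here, no step between two measured compounds is available to set the size of this change. Compound 2 already stands at the top of the measured range, and compound 1, which carries the hydroxy group, sits at its limit, so no movement beyond the usual scatter is expected from compound 2 to compound 3, and the step of no change at the digits printed from compound 2 to compound 3 (within the scatter) is expected to be flat. Compound 3 is therefore estimated at 100000 nM, within 40000 nM to 250000 nM.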

Compound 3, half-maximal inhibitory concentration: > 300000 nM
Compound 3 was reported as a limit; the forecaster's own chance of this, stated with the estimate: 65%; middle value at least 3.0-fold (0.47 log units) away from the limit.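

For the compounds shown here, the methyl on this oxygen is the first change here with a readable size: methoxy to hydroxy gives an at least 3.0-fold higher number from compound 2 to compound 3 (0.47 log units; beyond the scatter) in this assay, a move beyond the scatter that the earlier compounds, with no step between them, could not show. Compound 3 gives > 300000 nM, which is a limit of the assay and not a number. The step therefore has a floor but no measured top, because the reading of compound 3 stops at a limit: the limit of > 300000 nM in this assay, at which 1 of the 3 values shown sits.

Compound 1 and compound 3 differ in one place, but that step cannot be read, as both values are limits. Going by these compounds, whether a longer chain on this oxygen, such as ethyl, or an amine in place of the oxygen would lower the number remains open.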